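The source may report more compounds than this note shows. Statements on the series, on what has been measured and on what is new or still open speak of the compounds shown alone.

Compound 1 `CCn1c(C(=O)N[C@@H](C)C(=O)OC)ccc1C(CC)(CC)c1ccc(OCS(=O)(=O)c2ccccc2)c(C)c1` is the weakest point of the series in a functional assay on MCF7 cells (Homo sapiens) for antiproliferative activity, read by MTT assay, with a stated time of 24 h (a higher number here means a weaker inhibitor, a lower number a stronger inhibitor), where compound 1 gives 43700 nM. For the measured compounds named here, compound 3 `CCN(CC)CCNC(=O)c1ccc(C(CC)(CC)c2ccc(OCS(=O)(=O)c3ccccc3)c(C)c2)n1CC` gives 4680 nM in this assay, so the change a 9.3-fold lower number from compound 1 to compound 3 (0.97 log units; beyond the scatter) is the only measured step that leaves the ester. Compound 2 `CCn1c(C(=O)NCCC(=O)OC)ccc1C(CC)(CC)c1ccc(OCS(=O)(=O)c2ccccc2)c(C)c1` reaches only a limit of this assay, > 50000 nM, which is the limit described as the limit of > 50000 nM in this assay, at which 1 of the 3 values shown sits. Compound 4 `CCn1c(C(=O)N[C@H](C)CO)ccc1C(CC)(CC)c1ccc(OCS(=O)(=O)c2ccccc2)c(C)c1` differs from compound 1 by 1-(hydroxymethyl)ethyl in place of 1-(methoxycarbonyl)ethyl on an amide-type nitrogen. Going by the values given here, no measured step exchanges the ester for an alcohol on this nitrogen; the steps of an at least 1.1-fold higher number from compound 1 to compound 2 (0.05 log units; that floor lies within the scatter) and an at least 10-fold lower number from compound 2 to compound 3 (1.02 log units; beyond the scatter) involve other groups. The expected change in this assay is therefore small, a 1.5-fold lower number from compound 1 to compound 4 (0.16 log units; within the scatter). Compound 4 is estimated at 30000 nM, between 10000 nM and 80000 nM.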

Compound 4, half-maximal inhibitory concentration: 10600 nM
Beside the measured number, compound 4's estimate is 2.8-fold (0.45 log units) above it, within the range that was stated.
By their numbers in this assay, from the lowest: compound 3; then compound 4; then compound 1. At a limit, above all of these: compound 2.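

On the amide-type nitrogen, 1-(hydroxymethyl)ethyl in place of 1-(methoxycarbonyl)ethyl gives a 4.1-fold lower number from compound 1 to compound 4 (0.62 log units; beyond the scatter), so in this assay this position can gain without an amine entering. The 2-(diethylamino)ethyl group still stays ahead, with a 2.3-fold higher number from compound 3 to compound 4 (0.36 log units; beyond the scatter). Against the other ester the step is an at least 4.7-fold lower number from compound 2 to compound 4 (0.67 log units; beyond the scatter), which is only a floor: the limit of > 50000 nM in this assay, at which 1 of the 4 values shown sits.

Still open, as far as these compounds go, is whether a carboxylic acid or a 1-(aminomethyl)ethyl group on this nitrogen would follow the alcohol or the ester. From the compounds shown here alone, the mirror-image form of 1-(hydroxymethyl)ethyl and a longer hydroxyalkyl chain also remain open.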